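A few compounds are considered here, and "the series" means these few. Any claim that something is new, unique, unknown or untested is made for them only; others in the source may bear on it.

Three compounds have been measured so far in a physicochemical assay for solubility, read by HPLC, measured as kinetic solubility, with a stated time of 24 h, at pH 6.5 (a lower number here means a less soluble compound, a higher number a more soluble compound), as follows:

- Compound 1 `CC(C)(C)NCc1cc(Cl)cc(Nc2nc3cc(F)c(F)cc3n2Cc2ccc(C(F)(F)F)cc2)c1O` gives < 5000 nM as a limit of the assay, not a number
- Compound 2 `CCNCc1cc(Cl)cc(Nc2nc3cc(F)c(F)cc3[nH]2)c1O` gives 12000 nM as a number
- Compound 3 `CCN(CC)Cc1cc(C)cc(Nc2nc3ccccc3n2Cc2ccc(C(F)(F)F)cc2)c1O` gives < 5000 nM as a limit of the assay, not a number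

Among the measured compounds shown here, compound 2 holds the only true number in the set (12000 nM). The other two results are limits, so the series offers a single firm reference point. Attention now turns to compound 4 `CCNCc1cc(Cl)cc(Nc2nc3cc(F)c(F)cc3n2Cc2ccc(C(F)(F)F)cc2)c1O`, which has not yet been measured. It differs from compound 2 in one place, with 4-(trifluoromethyl)benzyl in place of hydrogen on an aromatic nitrogen.

For the measured compounds named here, no measured pair isolates this change. Compound 1 and compound 3 both carry the 4-(trifluoromethyl)benzyl group, but they also differ from compound 2 elsewhere. Both of them stand in the same place, (the limit of < 5000 nM in this assay, at which 2 of the 3 values shown sit), whereas compound 2, which lacks the group, gives a number. On that limited basis, a fall beyond the usual scatter is expected, and the assay may well report only a limit. The expected step is estimated as a 4.0-fold lower number from compound 2 to compound 4 (0.60 log units; beyond the scatter), starting from the value of compound 2 (12000 nM). The estimated value for compound 4 is 3000 nM, with an expected range of 1000 nM to 6000 nM.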

Compound 4, solubility: < 5000 nM
Compound 4: a limit, no number; the forecaster's own chance of this, stated with the estimate: 80%; the middle value is on the limit's open side.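

Among the compounds shown here, for the first time, the 4-(trifluoromethyl)benzyl group in place of hydrogen on an aromatic nitrogen stands as the only change between two compounds, and in this assay it gives an at least 2.4-fold lower number from compound 2 to compound 4 (0.38 log units; beyond the scatter). Compound 4 carries a limit of the assay and not a number, so this step has a firm lower bound on its size but no upper end. The step between compound 1 and compound 4, ethyl in place of tert-butyl on an amine nitrogen, cannot be read, as both results are the same limit: the limit of < 5000 nM in this assay, at which 3 of the 4 values shown sit.

The compounds shown leave open whether the fall goes with the whole 4-(trifluoromethyl)benzyl group or with part of it, which a plain benzyl or a small methyl on the same nitrogen would help to separate, as would a benzyl carrying a carboxylic acid or an amine in place of the trifluoromethyl. They also leave open how far compound 4 lies under its limit, and whether a different amine on the shared core would bring a compound with this group back to a readable number.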